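The compounds below may be only part of what the source reports. "The series", "measured", "known", "first", "only" and "open" are said of these compounds alone.

In a functional assay on HEL cells (Homo sapiens) for cytotoxicity, read by microscopy (a lower number here means that less compound is tolerated, a higher number that more compound is tolerated), compound 1 `COC(=O)CC(=O)NC1=CS(=O)(=O)O[C@@]12[C@@H](CO[Si](C)(C)C(C)(C)C)O[C@@H](n1cc(C)c(=O)n(C)c1=O)[C@@H]2O[Si](C)(C)C(C)(C)C` gives 400000 nM. Compound 2 `Cc1cn([C@@H]2O[C@H](CO[Si](C)(C)C(C)(C)C)[C@@]3(OS(=O)(=O)C=C3NCC(=O)OCc3ccccc3)[C@H]2O[Si](C)(C)C(C)(C)C)c(=O)n(C)c1=O` reaches only the limit of this assay, >= 400000 nM. Among the measured compounds shown here, the one measured step, a number no lower from compound 1 to compound 2 (the limit leaves the size open), is set by the limit of >= 400000 nM in this assay, at which 1 of the 2 values shown sits, and leaves its size open. For the measured compounds named here, compound 3 `COC(=O)C(=O)CNC1=CS(=O)(=O)O[C@@]12[C@@H](CO[Si](C)(C)C(C)(C)C)O[C@@H](n1cc(C)c(=O)n(C)c1=O)[C@@H]2O[Si](C)(C)C(C)(C)C` differs from compound 2 by methoxycarbonyl in place of benzyloxy on a carbonyl carbon, a smaller change at the same amine than that step, and no measured step bears on it directly. No shift beyond the scatter is expected, with a fair chance that this assay again reports only a limit. Compound 3 is therefore expected at 400000 nM in this assay, within 200000 nM to 800000 nM, a step of a number no higher from compound 2 to compound 3 (the limit leaves the size open).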

Compound 3, minimum cytotoxic concentration: > 400000 nM
Compound 3: a limit, no number; the forecaster's own chance of this, stated with the estimate: 60%; the middle value lies on the limit itself.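

In this assay, compound 3 gives > 400000 nM, a limit and not a number. On the amine nitrogen, ((methoxycarbonyl)carbonyl)methyl in place of ((methoxycarbonyl)methyl)carbonyl gives a number no lower from compound 1 to compound 3 (the limit leaves the size open), so a second replacement at this position also shows no lower value. Methoxycarbonyl in place of benzyloxy on a carbonyl carbon gives a step that cannot be read, and the benzyloxy ring can therefore be given no readable effect in this assay.

Still open, going by these compounds, is whether a carboxylic acid or an amine at this carbonyl carbon would give a number within the range of this assay.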